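This account rests on a few compounds, and the source may have more. Where it says the series, first, only, none or still open, it means among the compounds named here.

In a functional assay on cells (Platelet, Homo sapiens) for inhibition (a higher number here means a weaker inhibitor, a lower number a stronger inhibitor), three compounds built on one shared core have been tested, and none has yet given a number. Compound 1 `CCCOC(=O)c1ccc(-c2nn(Cc3ccccc3)c3ccccc23)cc1` reads > 10000 nM, which is a limit of the assay. Compound 2 `NC(=O)c1ccc(-c2nn(Cc3ccccc3)c3ccccc23)cc1` reads > 10000 nM, again a limit. Compound 3 `CNC(=O)c1ccc(-c2nn(Cc3ccccc3)c3ccccc23)cc1` reads > 10000 nM, also a limit, so it has no exact position. The whole record is the limit of > 10000 nM in this assay, at which 3 of the 3 values shown sit.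

Compound 4 `CCNC(=O)c1ccc(-c2nn(Cc3ccccc3)c3ccccc23)cc1` turns methylamino into ethylamino: methyl in place of hydrogen on a saturated chain carbon bound to an amide-type nitrogen. Within the data shown here, the closest precedent, a step that the two limits leave unreadable from compound 2 to compound 3, has no readable size, and neither have a step that the two limits leave unreadable from compound 1 to compound 2 and a step that the two limits leave unreadable from compound 1 to compound 3. No step in either direction can therefore be predicted with support from these data, so none beyond the scatter is expected in this assay. The expected result is a number no higher from compound 3 to compound 4 (the limit leaves the size open). Compound 4 is estimated at 10000 nM, within an expected range of 4000 nM to 30000 nM.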

Compound 4, half-maximal inhibitory concentration: > 10000 nM
Compound 4 ended at the assay's limit (the forecaster's own chance of this, stated with the estimate: 85%); the middle value lies on the limit itself.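

No step can be read among compound 1, compound 2, compound 3 and compound 4, since each stands only at a limit: the limit of > 10000 nM in this assay, at which 4 of the 4 values shown sit.

The compounds shown leave open whether any change to this shared core gives an exact number in this assay.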